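This account rests on a few compounds, and the source may have more. Where it says the series, first, only, none or still open, it means among the compounds named here.

Of the compounds shown here, three of a shared core have been measured in a functional assay on SK-BR-3 cells (Homo sapiens) for antiproliferative activity, read by MTT assay, with a stated time of 72 h; on this read-out lower numbers stand for stronger inhibition and higher numbers for weaker inhibition. Compound 1 `CCN1CCN(c2cc(C)c3cc(NC(=O)c4ccccc4F)ccc3n2)CC1` gives 38100 nM. Compound 2 `CCN(CC)CCNc1cc(C)c2cc(NC(=O)c3ccc(Cl)c(Cl)c3)ccc2n1` gives 3710 nM, and compound 3 `CCN1CCN(c2cc(C)c3cc(NC(=O)c4cc(Cl)cc(Cl)c4)ccc3n2)CC1` gives 2660 nM. Among these three numbers compound 2 stands second highest: its nearest neighbour is compound 3, whose number lies within the scatter of its own, while compound 1 lies far above it. Within the data shown here, the only step between compounds that differ in one place is the exchange of the aryl group on the carbonyl, which gave a 14-fold lower number from compound 1 to compound 3 (1.16 log units; beyond the scatter).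

The next compound, compound 4 `Cc1cc(N2CCN(C(C)C)CC2)nc2ccc(NC(=O)c3ccc(Cl)c(Cl)c3)cc12`, differs from compound 2 by 4-isopropylpiperazin-1-yl in place of (2-(diethylamino)ethyl)amino on an aromatic carbon. Among the measured compounds shown here, no measured step touches this part of the molecule alone. Compound 2 and compound 3 differ both here and on the carbonyl aryl group, so their pair cannot be read as a single step; all that can be said is that their two values lie within the scatter of each other. With nothing pointing either way, no step beyond the scatter is expected from compound 2 to compound 4 in this assay, and the expected step is a 1.2-fold lower number from compound 2 to compound 4 (0.06 log units; within the scatter). Compound 4 is therefore estimated at 3200 nM, within a range of 1200 nM to 8500 nM.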

Compound 4, half-maximal inhibitory concentration: 6680 nM
Compound 4: the middle estimate sits 2.1-fold (0.32 log units) below what was measured; measured number inside the range.
By their numbers in this assay, from the lowest: compounds 3, 2 and 4 (each within the scatter of the next, the first and the last beyond it); then compound 1.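

Among these compounds, this is the first change at this place on its own, on the aromatic carbon next to the ring nitrogen, with the rest of the molecule held fixed. In this assay, the open chain gives way to a six-membered non-aromatic ring and the hydrogen-bond donor of the leaving group is gone, yet the result is a 1.8-fold higher number from compound 2 to compound 4 (0.26 log units; within the scatter), so this pair does not separate the two groups, even though they differ in shape and donor count. The data shown offer no measurement that would explain why this exchange leaves the number within the scatter.

Going by these compounds, one pair cannot show whether this place accepts other groups in general, so it remains open whether a morpholin-4-yl ring, with an oxygen in place of one ring nitrogen, or a plain amino group would also stay within the scatter of compound 2. Among the compounds shown here, it is also open whether the same exchange would behave alike with a different aryl group on the carbonyl, given that the one step at that part of the molecule, a 14-fold lower number from compound 1 to compound 3 (1.16 log units; beyond the scatter), is far larger.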